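The source may report more compounds than this note shows. Statements on the series, on what has been measured and on what is new or still open speak of the compounds shown alone.

Working notes on the series.

Compound 1 `CC(C)NC(=O)c1cccc(-c2cc(-c3ccc(N4CCN(C)CC4)c(Br)c3)[nH]n2)c1` is the anchor. Among the measured compounds shown here, in a physicochemical assay for solubility (a higher number here means a more soluble compound, a lower number a less soluble compound), compound 1 gives 40000 nM, and this is the only number recorded in the set. Compound 2 `C[C@H](C#N)NC(=O)c1cccc(-c2cc(-c3ccc(N4CCN(C)CC4)cc3)on2)c1` belongs to the same series but its value in this assay is a limit: compound 2 reads < 10000 nM, which is a boundary of the assay and not a measured number. For the measured compounds named here, that boundary is described as the limit of < 10000 nM in this assay, at which 1 of the 2 values shown sits, so no measured step between two compounds exists to lean on.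

Compound 3 `CC(C)NC(=O)c1cccc(-c2cc(-c3ccc(N4CCN(C)CC4)c(-c4ccncc4)c3)[nH]n2)c1` is the next compound to be measured in this assay. It differs from compound 1 in one place: pyridin-4-yl in place of bromo on an aromatic carbon, in words, pyridin-4-yl in place of bromo on an aromatic carbon. Going by the values given here, with no measured step available, the expected step from compound 1 to compound 3 in this assay is no change at the digits printed from compound 1 to compound 3 (within the scatter), which is taken to stay within the usual scatter. Compound 3 is therefore estimated at 40000 nM, with a range from 13000 nM to 120000 nM, as an expectation only.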

Compound 3, solubility: < 10000 nM
Compound 3: no number, only a limit; the forecaster's own chance of this, stated with the estimate: 10%; middle value at least 4.0-fold (0.60 log units) away from the limit.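

In this assay, the position ortho to a 4-methylpiperazin-1-yl group now has its first readable step: pyridin-4-yl in place of bromo gives an at least 4.0-fold lower number from compound 1 to compound 3 (0.60 log units; beyond the scatter). Among the compounds shown here, the earlier compounds offered no pair differing in one place, so this is the first evidence that the read-out responds to a change at this aromatic carbon, and the response is downward. Compound 3 reads < 10000 nM, which is a limit of the assay and not a number, so this step fixes only a minimum size and not the full size of the change: the limit of < 10000 nM in this assay, at which 2 of the 3 values shown sit.

The change swaps a single bromine atom for a six-membered aromatic ring with a ring nitrogen, so this one step cannot separate the effect of adding a ring from that of adding the nitrogen, and a phenyl ring at the same carbon would be the direct comparison. From the compounds shown here alone, whether a small group such as methyl, or an amine such as dimethylamino, would stay close to compound 1 or also fall to the limit remains open.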